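Trading a Fluorinated Aryl for a Methylated One

The source may hold more compounds than are shown below. What is called first, only, known or untested is meant among the compounds shown, and "the series" means these compounds.

Compound 1 `C[C@H]1CC/C(=N\Nc2ccccc2)c2ncc(C(=O)O)c(=O)n21` and compound 2 `CC1CCC(/C=N/c2ccccc2F)=C2NC=C(C(=O)O)C(=O)N21` have both been tested in a functional assay on the whole organism with Rattus norvegicus as the target; a higher number here means that more compound is needed for the effect, a lower number that less compound is needed. Compound 1 gives 0.3 umol/kg in this assay, while compound 2 gives 14.5 umol/kg, the higher of the two numbers, with a gap beyond the scatter; since the two structures differ in more than one place, only the two values themselves can be set side by side. Compound 3 `Cc1ccc(/N=C/C2=C3NC=C(C(=O)O)C(=O)N3C(C)CC2)cc1` carries the change (4-methylphenyl in place of 2-fluorophenyl on a double-bonded nitrogen). Among the compounds with values here, with no single-point step to lean on, the step of a 1.5-fold lower number from compound 2 to compound 3 (0.16 log units; within the scatter) is expected to stay within the scatter. Compound 3 is accordingly estimated at about 10 umol/kg, within 2.5 umol/kg to 40 umol/kg.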

Compound 3, dose for 50% inhibition: 3.6 umol/kg
Compound 3: middle estimate off by 2.8-fold (0.44 log units), on the high side; low and high end bracket the measured number.
By their numbers in this assay, from the lowest: compound 1; then compound 3; then compound 2.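

The aryl group on the double-bonded nitrogen matters in this assay: 4-methylphenyl in place of 2-fluorophenyl gives a 4.0-fold lower number from compound 2 to compound 3 (0.61 log units; beyond the scatter). Within the data shown here, this is the first change here confined to one place. The two groups match in heavy-atom count and hydrogen-bond donors and acceptors, so those counts do not separate them, and no measurement at hand accounts for the step.

Still open, as far as these compounds go, is whether the step follows the group itself or its ring position, which 2-methylphenyl and 4-fluorophenyl would separate. From the compounds shown here alone, how a methoxy group or an amine on that ring would read also remains open.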